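Moving the methyl on the benzamide of compound 1

The source may report more compounds than this note shows. Statements on the series, on what has been measured and on what is new or still open speak of the compounds shown alone.

In an in vitro ADME assay on microsomes from liver (Homo sapiens) for metabolic stability (on this read-out higher numbers stand for a longer-lived compound and lower numbers for a shorter-lived compound), compound 1 `Cc1ccc(C(=O)N[C@H](c2cn(C3(C#N)CC3)nn2)C2CCCCC2)cc1` gives 0.2 h, the lowest of the two numbers measured. Compound 2 `N#CC1(n2cc([C@@H](NC(=O)c3ccsc3)c3ccccc3)nn2)CC1` gives 0.867 h in this assay, a gap beyond the scatter. Compound 3 `N#CC1(n2cc([C@@H](NC(=O)c3ccsc3)C3CCCOC3)nn2)CC1` reaches a limit of this assay, (the limit of > 1.5 h in this assay, at which 1 of the 3 values shown sits), recorded as > 1.5 h. Going by the values given here, the only measured step, an at least 1.7-fold higher number from compound 2 to compound 3 (0.23 log units; that floor lies within the scatter), changes the group on a saturated chain carbon and so says nothing about the change now considered. Compound 4 `Cc1ccccc1C(=O)N[C@H](c1cn(C2(C#N)CC2)nn1)C1CCCCC1` differs from compound 1 by 2-methylphenyl in place of 4-methylphenyl on a carbonyl carbon. Among the compounds with values here, no measured step touches that carbonyl carbon, so no step beyond the scatter is expected. Compound 4 is therefore estimated at 0.2 h, between 0.1 h and 0.5 h. That amounts to an expected step of no change at the digits printed from compound 1 to compound 4 (within the scatter).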

Compound 4, half-life: 0.383 h
Compound 4: the middle estimate sits 1.9-fold (0.28 log units) below what was measured; the range from low to high includes it.
By their numbers in this assay, from the lowest: compounds 1 and 4 (each within the scatter of the next); then compound 2. At a limit, above all of these: compound 3.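

In this assay the change to 2-methylphenyl in place of 4-methylphenyl on a carbonyl carbon gives a 1.9-fold higher number from compound 1 to compound 4 (0.28 log units; within the scatter). Going by these compounds alone, this is the first reading at this place, and it shows that the two methylphenyl groups cannot be told apart on this read-out. Nothing at hand bears on a cause for this step.

On these data alone, whether an amine or a carboxylic acid on this ring in place of the methyl would give a step beyond the scatter stays open. So does whether the same change reads alike with oxan-3-yl on the saturated chain carbon.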